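Replacing an Aryl with an Arylsulfonyl on the Ring Nitrogen

A few compounds are considered here, and "the series" means these few. Any claim that something is new, unique, unknown or untested is made for them only; others in the source may bear on it.

Measured compounds:
- compound 1 `O=C(/C=C/c1ccccc1)c1ccc(N2CCN(c3cccc(Cl)c3)CC2)cc1`: 14.1%
- compound 2 `COc1ccc(N2CCN(c3ccc(C(=O)/C=C/c4ccc(Cl)cc4)cc3)CC2)cc1`: 55.1%
- compound 3 `COc1ccccc1N1CCN(c2ccc(C(=O)/C=C/c3ccc(Cl)cc3)cc2)CC1`: 6.13%

Three compounds sharing one core were tested in a functional assay on the whole organism (strain Kunming) for inhibition, with Mus musculus as the target, with a stated time of 1 h, at a dose of 40 mg/kg by the oral route; on this read-out higher numbers stand for more inhibition at the one dose given (going by the name of the read-out) and lower numbers for less inhibition. Compound 2 gives 55.1%, the highest of the three. Compound 1 gives 14.1%, the second highest; compound 3 gives 6.13%, which lies within the scatter of compound 1, so the two cannot be ordered. Compound 2 stands well above compound 1.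

For the measured compounds named here, the only single step seen so far is a number 49 percentage points lower from compound 2 to compound 3 (beyond the scatter), a large drop from moving the methoxy group on the phenyl ring to a different position.

Compound 4 `O=C(/C=C/c1ccccc1)c1ccc(N2CCN(S(=O)(=O)c3ccc(Cl)cc3)CC2)cc1` differs from compound 1 as follows: (4-chlorophenyl)sulfonyl in place of 3-chlorophenyl on an amine nitrogen in a ring. Going by the values given here, no measured step in this set changes an aromatic group into a sulfonyl-linked one on the ring nitrogen, so the step from compound 2 to compound 3 gives no guidance on direction here. What is known is only that the parent, compound 1, sits low.

Compound 4 is therefore estimated at 15%, with a range from 0% to 45%, which means an expected step of a number 0.9 percentage points higher from compound 1 to compound 4 (within the scatter) that need not exceed the scatter.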

Compound 4, a percentage reported as inhibition, in the whole organism at one dose (the size of the read-out at that dose, not a potency): 46.8%
Compound 4: the middle estimate sits 31.8 percentage points below what was measured, and the stated range ends below it.
By their numbers in this assay, from the lowest: compounds 3 and 1 (each within the scatter of the next); then compounds 4 and 2 (each within the scatter of the next).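

In this assay putting (4-chlorophenyl)sulfonyl in place of 3-chlorophenyl on the amine nitrogen in the ring gives a number 32.7 percentage points higher from compound 1 to compound 4 (beyond the scatter) and so marks a large gain at this position. For the compounds shown here, the only earlier step kept a methoxyphenyl group on this nitrogen and moved the methoxy group around that ring, whereas this step shows that the group need not be a phenyl ring attached directly to the nitrogen: with a sulfonyl link in place, the phenyl ring is held one atom further out and the read-out rises rather than falls. Nothing measured here explains why the number rises, so the gain stands as an observation without a cause.

This single step changes two things at once, the sulfonyl link and the place of the chlorine, so the compounds shown cannot say which of them carries the gain, and a (3-chlorophenyl)sulfonyl group on the same nitrogen would separate the two. They also leave open whether the sulfonyl link itself is needed or whether a 4-chlorobenzoyl group, with a carbonyl as the link, would serve as well, and whether a methanesulfonyl group would hold up without the aromatic ring.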